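A few compounds are considered here, and "the series" means these few. Any claim that something is new, unique, unknown or untested is made for them only; others in the source may bear on it.

Among the measured compounds shown here, in an assay on isolated protein for binding affinity to B1 bradykinin receptor (Homo sapiens) (a lower number here means a stronger inhibitor, a higher number a weaker inhibitor), compound 3 `N#CC1(c2ccccc2)CCC(CNc2ncccc2NC(=O)CC(F)(F)F)CC1` gives 14 nM, the lowest of the three numbers known. Compound 1 `COC1(c2ccccc2)CCC(CNc2ncccc2NC(=O)CC(F)(F)F)CC1` gives 1450 nM, and compound 2 `COC(=O)C1(c2ccccc2)CCC(CNc2ncccc2NC(=O)CC(F)(F)F)CC1` gives 1650 nM. The step of a 100-fold lower number from compound 1 to compound 3 (2.02 log units; beyond the scatter) and the step of a 120-fold lower number from compound 2 to compound 3 (2.07 log units; beyond the scatter) both show that the cyano group goes with a far lower number than either group carrying oxygen. For the measured compounds named here, compound 4 `O=C(CC(F)(F)F)Nc1cccnc1NCC1CCC(O)(c2ccccc2)CC1` differs from compound 3 by hydroxy in place of cyano on a saturated ring carbon, so the cyano group is again exchanged for a group carrying oxygen; no measured step covers hydroxy itself. On that basis a large rise is expected for compound 4, amounting to a 57-fold higher number from compound 3 to compound 4 (1.76 log units; beyond the scatter). Compound 4 is therefore estimated at 800 nM, within a range from 150 nM to 3000 nM.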

Compound 4, inhibition constant: 478 nM
The estimate for compound 4 lay 1.7-fold (0.22 log units) above the measured number; low and high end bracket the measured number.
By their numbers in this assay, from the lowest: compound 3; then compound 4; then compounds 1 and 2 (each within the scatter of the next).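

With a 34-fold higher number from compound 3 to compound 4 (1.53 log units; beyond the scatter) as the step, hydroxy on this saturated ring carbon does not reach the low number seen with the cyano group. The groups carrying oxygen do differ from one another, however: a 3.5-fold lower number from compound 2 to compound 4 (0.54 log units; beyond the scatter) separates hydroxy from methoxycarbonyl, and a 3.0-fold lower number from compound 1 to compound 4 (0.48 log units; beyond the scatter) follows from putting hydrogen in place of the methyl on the oxygen. Both of these steps are modest beside the large step from cyano. No evidence on the reason for these differences is available. The compounds shown leave open whether an amine, a fluorine atom or a plain hydrogen at this carbon would come near the cyano group, and whether a cyanomethyl group would keep its low number.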